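The source may hold more compounds than are shown below. What is called first, only, known or untested is meant among the compounds shown, and "the series" means these compounds.

Three compounds built on one shared core have been compared in an assay on HEK293 cells for displacement of a labelled ligand from Melanocortin receptor 4 (Homo sapiens); on this read-out lower numbers stand for stronger inhibition and higher numbers for weaker inhibition. Compound 1, `CC(C)C[C@H](N)c1cc(C(F)(F)F)ccc1N1CCN(C(=O)CC(C)C(=O)c2ccc(Cl)cc2)CC1`, gives 1100 nM, the highest of the three numbers. Compound 2, `CC(C)C[C@H](N)c1cc(F)ccc1N1CCN(C(=O)C(C)Cc2ccc(Cl)cc2)CC1`, gives 390 nM, and compound 3, `COc1cc(Cl)ccc1CC(C)C(=O)N1CCN(c2ccc(Cl)cc2[C@@H](N)CC(C)C)CC1`, gives 9.1 nM; both of these differences from compound 1 lie beyond the scatter. Compound 4, `COc1ccc(CC(C)C(=O)N2CCN(c3ccc(C(F)(F)F)cc3[C@@H](N)CC(C)C)CC2)cc1`, has not yet been measured in this assay. It differs from compound 1 in one place: 1-(4-methoxybenzyl)ethyl in place of 2-((4-chlorophenyl)carbonyl)propyl on a carbonyl carbon. Compound 2 and compound 3, which also do without the chain that leaves, both give lower numbers than compound 1, so a fall beyond the scatter is expected, a 7.3-fold lower number from compound 1 to compound 4 (0.87 log units; beyond the scatter), although the trifluoromethyl group of compound 1 is kept. Compound 4 is estimated at 150 nM, within a range from 40 nM to 600 nM.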

Compound 4, inhibition constant: 120 nM
Beside the measured number, compound 4's estimate is 1.3-fold (0.10 log units) above it; the measured number falls inside the stated range.
By their numbers in this assay, from the lowest: compound 3; then compound 4; then compound 2; then compound 1.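

On a carbonyl carbon whose other neighbour is an amide-type nitrogen in a ring, putting 1-(4-methoxybenzyl)ethyl in place of 2-((4-chlorophenyl)carbonyl)propyl gives in this assay a 9.2-fold lower number from compound 1 to compound 4 (0.96 log units; beyond the scatter) with the rest of the molecule unchanged. Among the compounds shown here, this is the first single-place step, and it shows that this chain alone can move the number beyond the scatter. Nothing measured here explains the shift. The compounds shown leave open whether the methoxy group, the lost chain carbonyl or the lost chlorine matters most, as all three change together. They also leave open how an amine or a carboxylic acid in place of the methoxy group would read.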